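Two methyls in place of one methoxy group

The compounds below may be only part of what the source reports. "The series", "measured", "known", "first", "only" and "open" are said of these compounds alone.

Three measured compounds share one core. In a functional assay on HT-29 cells (Homo sapiens) for antiproliferative activity, read by MTT assay, with a stated time of 48 h (a lower number here means a stronger inhibitor of growth, a higher number a weaker inhibitor of growth), compound 1 `S=C(Nc1ccccc1)N1N=C(c2ccc(Cl)cc2)CC1c1ccc2c(c1)OCCO2` gives 187000 nM. Compound 2 `Cc1ccc(C2=NN(C(=S)Nc3ccccc3)C(c3ccc4c(c3)OCCO4)C2)cc1` gives 19500 nM, and compound 3 `COc1cccc(C2=NN(C(=S)Nc3ccccc3)C(c3ccc4c(c3)OCCO4)C2)c1` gives 2920 nM, the lowest of the three numbers. Compound 4 `Cc1ccc(C2=NN(C(=S)Nc3ccccc3)C(c3ccc4c(c3)OCCO4)C2)cc1C` differs from compound 3 by 3,4-dimethylphenyl in place of 3-methoxyphenyl on a carbon with a double bond to nitrogen. Among the measured compounds shown here, two measured steps bear on this change: a 6.7-fold lower number from compound 2 to compound 3 (0.82 log units; beyond the scatter) shows that a methoxy group in place of a methyl lowered the number, and a 9.6-fold lower number from compound 1 to compound 2 (0.98 log units; beyond the scatter) shows that a methyl in place of chloro also lowered it. Removing the methoxy while adding a second methyl is therefore expected to raise the number in this assay, though not by the full reversal. Compound 4 is estimated at 8000 nM, within a range of 2500 nM to 25000 nM, an expected step of a 2.7-fold higher number from compound 3 to compound 4 (0.44 log units; beyond the scatter).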

Compound 4, concentration for 50% growth inhibition: 133000 nM
Compound 4: middle estimate off by 17-fold (1.22 log units), on the low side; measured number outside the range, above it.
By their numbers in this assay, from the lowest: compound 3; then compound 2; then compounds 4 and 1 (each within the scatter of the next).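

In this assay, among the compounds shown here, a second methyl on the aromatic ring is not neutral: a 6.8-fold higher number from compound 2 to compound 4 (0.83 log units; beyond the scatter) shows that this one added methyl raises the number, which no earlier step could show. Leaving 3-methoxyphenyl for 3,4-dimethylphenyl therefore costs far more than the earlier steps suggested, a 46-fold higher number from compound 3 to compound 4 (1.66 log units; beyond the scatter), and the 3,4-dimethylphenyl and 4-chlorophenyl groups cannot be told apart, a 1.4-fold lower number from compound 1 to compound 4 (0.15 log units; within the scatter). No measurement here explains this sharp rise. Still open, as far as these compounds go, is whether the low number of compound 3 follows the methoxy group itself or its place on the ring, and whether a hydroxyl or an amine there would lower the number further.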